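A few compounds are considered here, and "the series" means these few. Any claim that something is new, unique, unknown or untested is made for them only; others in the source may bear on it.

Working notes on the series. Compound 1 `COc1ccc(-c2cnc(NC(=O)c3ccco3)n2C)cc1`, compound 2 `COc1ccc(-c2cnc(NC(=O)c3cccc(C#N)c3)n2C)cc1` and compound 3 `COc1ccc(-c2cnc(NC(=O)C3CCOCC3)n2C)cc1` share one core and differ only in the group on the carbonyl carbon. All three were run in a toxicity assay on THP-1 cells (Homo sapiens) for inhibition; on this read-out lower numbers stand for higher toxicity in this test and higher numbers for lower toxicity in this test. Compound 1 gives > 100000 nM, which is a limit of the assay rather than a number. Compound 2 likewise gives > 100000 nM, a limit. Compound 3 gives > 100000 nM, again a limit. Compound 3 therefore stands where the other two stand, at the limit of > 100000 nM in this assay, at which 3 of the 3 values shown sit, and no ordering among the three can be read. The steps between them are accordingly unreadable in size: a step that the two limits leave unreadable from compound 1 to compound 2, a step that the two limits leave unreadable from compound 1 to compound 3 and a step that the two limits leave unreadable from compound 2 to compound 3.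

Compound 4 `COc1ccc(-c2cnc(NC(=O)c3ccc(Br)cc3)n2C)cc1` is not yet measured. It differs from compound 3 in one place: 4-bromophenyl in place of oxan-4-yl on a carbonyl carbon. The measured steps that bear on this change all concern an exchange of the group on the carbonyl carbon, and each is unreadable; none of the three measured groups produced a readable number in this assay. The expectation for compound 4 is therefore no step beyond the scatter, an estimated a number no higher from compound 3 to compound 4 (the limit leaves the size open), resting on compound 3 sitting at the limit of > 100000 nM in this assay, at which 3 of the 3 values shown sit. Compound 4 is expected to give 100000 nM, with a range from 30000 nM to 300000 nM, most probably reported as a limit once more.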

Compound 4, half-maximal cytotoxic concentration: > 100000 nM
Compound 4 ended at the assay's limit (the forecaster's own chance of this, stated with the estimate: 80%); the middle value sits exactly at the limit.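

In this assay compound 4 sits with compounds 1, 2 and 3 at the limit, so no step between compound 4 and any of these three can be read: the limit of > 100000 nM in this assay, at which 4 of the 4 values shown sit.

The compounds shown leave open whether any group on the carbonyl carbon gives a readable value in this assay, and how these four compounds rank.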